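Aryl sulfone variation in a receptor-binding series

The compounds below may be only part of what the source reports. "The series", "measured", "known", "first", "only" and "open" are said of these compounds alone.

Measured compounds:
compound 1 `CC1CCN(c2c(S(=O)(=O)c3ccc(Cl)c(Cl)c3)cnc3ccc(Cl)cc23)CC1`: 86%
compound 2 `COc1cccc(S(=O)(=O)c2cnc3ccc(Cl)cc3c2N2CCC(C)CC2)c1`: 87%
compound 3 `Cc1ccc(S(=O)(=O)c2cnc3ccc(Cl)cc3c2N2CCC(C)CC2)cc1`: 95%

All three were tested in an assay on isolated protein for displacement of a labelled ligand from metabotropic glutamate receptor 5 (Homo sapiens), with a stated time of 60 min, tested at 1 uM (a lower number here means less inhibition, a higher number more inhibition at the concentration tested (going by the name of the read-out)), and share one core, differing only in the aryl group on the sulfonyl sulfur. Compound 3 gives the highest of the three numbers, but its separation from compound 2 a number 8 percentage points higher from compound 2 to compound 3 (within the scatter) and from compound 1 a number 9 percentage points higher from compound 1 to compound 3 (within the scatter) stays within the scatter, so no order among the three can be claimed. The remaining step of a number 1 percentage points higher from compound 1 to compound 2 (within the scatter) is likewise within the scatter.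

Compound 4 `CC1CCN(c2c(S(=O)(=O)c3cc(F)cc(F)c3)cnc3ccc(Cl)cc23)CC1` has not yet been measured. It differs from compound 3 as follows: 3,5-difluorophenyl in place of 4-methylphenyl on a sulfonyl sulfur. Every measured step bears on this change, since each swaps the aryl group at the same position, and none of them moved the read-out beyond the scatter. The expectation is therefore a step of a number 9 percentage points lower from compound 3 to compound 4 (within the scatter) that stays within the scatter, with a slight lean downward only because compound 3 95% sits at the top of the measured range. Compound 4 is expected to give 86%, estimated between 72% and 96%.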

Compound 4, a percentage reported as inhibition, at one concentration (the size of the read-out at that concentration, not a potency): 93%
The estimate for compound 4 lay 7 percentage points below the measured number; the measured number falls inside the stated range.
By their numbers in this assay, from the lowest: compounds 1, 2, 4 and 3 (each within the scatter of the next).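

In this assay the change to 3,5-difluorophenyl on a sulfonyl sulfur gives a number 2 percentage points lower from compound 3 to compound 4 (within the scatter) and also a number 6 percentage points higher from compound 2 to compound 4 (within the scatter) and a number 7 percentage points higher from compound 1 to compound 4 (within the scatter). The earlier compounds shown here covered only methyl, methoxy and chloro substitution on the phenyl ring; a phenyl ring carrying two fluorines now also stays within the scatter of all three, so no step at this position has yet moved the read-out beyond it. Nothing available explains why these four aryl groups read alike.

On these data alone, whether a phenyl ring bearing a carboxylic acid or an amine, or a plain methyl or longer alkyl chain on the sulfonyl sulfur, would separate from these numbers remains open. As far as these compounds go, with a single tested concentration, any difference in potency among the four compounds also remains open.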